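From tert-butyl to chloro on the aromatic ring

The source may report more compounds than this note shows. Statements on the series, on what has been measured and on what is new or still open speak of the compounds shown alone.

Within the data shown here, in a functional assay on MDA-MB-231 cells (Homo sapiens) for antiproliferative activity, read by MTT assay, with a stated time of 72 h (on this read-out higher numbers stand for weaker inhibition and lower numbers for stronger inhibition), compound 1 (`CC(C)(C)c1ccc(OCCCON2C(N)=NC(N)=NC23CCSCC3)cc1`) gives 1 nM and holds the lowest of the two numbers so far. Compound 2 (`NC1=NC2(CCOCC2)N(OCCCOc2cccc(Cl)c2)C(N)=N1`) gives 1020 nM in this assay as the nearest value, a gap beyond the scatter. Compound 2 carries a chloro group but differs from compound 1 in more than one place, so that pair isolates no single change.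

Compound 3 (`NC1=NC2(CCSCC2)N(OCCCOc2ccc(Cl)cc2)C(N)=N1`) keeps the core of compound 1 and has chloro in place of tert-butyl on an aromatic carbon, para to a large group (chloro in place of tert-butyl on an aromatic carbon). Among the measured compounds shown here, no measured single-change step is available to size this. In this assay, for the measured compounds named here, a step toward weaker inhibition and beyond the scatter is expected, based only on compound 2 at 1020 nM as the one chloro-bearing value. The estimated step is a 40-fold higher number from compound 1 to compound 3 (1.60 log units; beyond the scatter) in this assay and remains smaller than the gap between the measured pair. For compound 3 the estimated value is 40 nM with an expected range from 4 nM to 400 nM in this assay.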

Compound 3, half-maximal inhibitory concentration: 350 nM
For compound 3 the middle estimate is 8.8-fold (0.94 log units) below the measured one; the range from low to high includes it.
By their numbers in this assay, from the lowest: compound 1; then compound 3; then compound 2.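

Among these compounds, with the core of compound 1 held fixed, chloro in place of tert-butyl on an aromatic carbon, para to a large group, gives in this assay a step of a 350-fold higher number from compound 1 to compound 3 (2.54 log units; beyond the scatter) and this is the first single-change step. It shows that the read-out is highly sensitive to the group at this position, with the tert-butyl compound giving the much lower number. No available evidence bears on what lies behind the size of this step.

With only tert-butyl and chloro shown at this position, the step is one comparison and defines no trend. On these data alone, how a methoxy group, an amine or a carboxylic acid would read at this position in this assay stays open.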